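Adding a Phenyl to Compound 2: An Expected Value

This account rests on a few compounds, and the source may have more. Where it says the series, first, only, none or still open, it means among the compounds named here.

Compound 1 `COc1cc(OC)c(/C=C/S(=O)(=O)Nc2ccc(OC)c(F)c2)c(OC)c1` is tested in a functional assay on DU-145 cells (Homo sapiens) for cytotoxicity, read by trypan blue exclusion, with a stated time of 96 h (on this read-out lower numbers stand for stronger inhibition and higher numbers for weaker inhibition), and compound 1 gives 200 nM. Compound 2 `COC(=O)CNc1cc(NS(=O)(=O)/C=C/c2c(OC)cc(OC)cc2OC)ccc1OC` carries a ((methoxycarbonyl)methyl)amino group in place of the fluoro on an aromatic carbon, and in this assay compound 2 gives 350 nM. The step of a 1.8-fold higher number from compound 1 to compound 2 (0.24 log units; within the scatter) is the only one measured, so the two numbers cannot be told apart, and compound 2 stands level with compound 1 on what is shown.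

Compound 3 `COC(=O)C(Nc1cc(NS(=O)(=O)/C=C/c2c(OC)cc(OC)cc2OC)ccc1OC)c1ccccc1` differs from compound 2 by phenyl in place of hydrogen on a saturated chain carbon bound to a carbonyl carbon and a nitrogen on an aromatic ring. Within the data shown here, no measured step touches this place; the one step in hand concerns a change on the aromatic carbon and was itself within the scatter, so it gives no direction for the phenyl. Compound 3 is therefore expected to stay close to compound 2, with the step of a 1.3-fold higher number from compound 2 to compound 3 (0.11 log units; within the scatter) estimated as no change beyond the scatter. In this assay compound 3 is estimated at 450 nM, with a range from 150 nM to 1400 nM.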

Compound 3, half-maximal inhibitory concentration: 2500 nM
Compound 3: middle estimate off by 5.6-fold (0.74 log units), on the low side; measured number above the stated range.
By their numbers in this assay, from the lowest: compounds 1 and 2 (each within the scatter of the next); then compound 3.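

In this assay the phenyl in place of hydrogen on a saturated chain carbon bound to a carbonyl carbon and a nitrogen on an aromatic ring gives a 7.1-fold higher number from compound 2 to compound 3 (0.85 log units; beyond the scatter) and so lies beyond the scatter, which makes this carbon the first place among these compounds where a single change separates two numbers. The comparison with the fluoro compound shifts as well: the ((methoxycarbonyl)methyl)amino group in place of fluoro could not be told apart from it, whereas the group of 12 heavy atoms that includes the phenyl gives a 13-fold higher number from compound 1 to compound 3 (1.10 log units; beyond the scatter) and is clearly separated from it. Nothing measured here accounts for the rise at this carbon.

The compounds shown leave open whether a small group such as methyl on the same carbon would also raise the number, or whether the rise goes with the six-membered aromatic ring itself. They also leave open how a carboxylic acid in place of the methoxycarbonyl would read, with or without the phenyl on this carbon.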